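The compounds below may be only part of what the source reports. "The series", "measured", "known", "first", "only" and "open" are said of these compounds alone.

Working notes on the series.

Compound 1 `COc1cc(/C=C/C(=O)C2=C(/C=C/c3ccc(O)c(OC)c3)NC(=O)NC2c2ccc(N(C)C)cc2)ccc1O` gives 56% in a functional assay, with a stated time of 20 min, tested at 50 uM; on this read-out lower numbers stand for a weaker effect and higher numbers for a stronger effect at the one concentration tested. Compound 2 `COc1cc(/C=C/C(=O)C2=C(/C=C/c3ccc(O)c(OC)c3)NC(=O)NC2c2c(Cl)cccc2Cl)ccc1O` gives 43.2% in this assay; the change is 2,6-dichlorophenyl in place of 4-(dimethylamino)phenyl on a saturated ring carbon, and the step is a number 12.8 percentage points lower from compound 1 to compound 2 (beyond the scatter). Compound 3 `COc1cc(/C=C/C(=O)C2=C(/C=C/c3ccc(O)c(OC)c3)NC(=S)NC2c2ccc(N(C)C)cc2)ccc1O` gives 89.5% in this assay, the highest of the three numbers; compound 1 stands nearest to it and compound 2 furthest, both beyond the scatter. How the core of compound 3 differs from that of compound 1 is not broken down here.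

Compound 4 `COc1cc(/C=C/C(=O)C2=C(/C=C/c3ccc(O)c(OC)c3)NC(=S)NC2c2c(Cl)cccc2Cl)ccc1O` is not yet measured. It differs from compound 3 by 2,6-dichlorophenyl in place of 4-(dimethylamino)phenyl on a saturated ring carbon, the same change as that from compound 1 to compound 2, occurring twice among the compounds shown. Among the compounds with values here, the estimated step of a number 12.5 percentage points lower from compound 3 to compound 4 (beyond the scatter) is taken to resemble the measured one, because a number 12.8 percentage points lower from compound 1 to compound 2 (beyond the scatter) is the only measured instance of this change and no other pair shows it. For compound 4 the expected value in this assay is 77%, with a range estimated from 60% to 92%.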

Compound 4, a percentage reported as activity, at one concentration (the size of the read-out at that concentration, not a potency): 50.2%
Compound 4: the middle estimate sits 26.8 percentage points above what was measured; measured number outside the range, below it.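

Putting 2,6-dichlorophenyl in place of 4-(dimethylamino)phenyl on a saturated ring carbon gives a number 39.3 percentage points lower from compound 3 to compound 4 (beyond the scatter) in this assay. The number falls on both cores, but the size of the step does not carry over from one core to the other: the same change on two cores in this assay, a number 12.8 percentage points lower (beyond the scatter) from compound 1 to compound 2 and a number 39.3 percentage points lower (beyond the scatter) from compound 3 to compound 4, 26.5 percentage points apart, beyond the scatter of two such steps. A step measured on one core therefore gave the direction on the other but not a usable size, and two pairs do not show what in the cores sets the gap, nor whether it would hold for any other pair of groups.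

The compounds shown leave open whether the gap belongs to these two aryl groups alone, since each core is seen with only 4-(dimethylamino)phenyl and 2,6-dichlorophenyl on that carbon. An unsubstituted phenyl or a pyridine ring there, carried on both cores, would show whether the steps on the two cores stay apart or come together.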